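Working notes: aryl exchange on compound 2

The source may hold more compounds than are shown below. What is called first, only, known or untested is meant among the compounds shown, and "the series" means these compounds.

compound 1 `CCOCCOC(=O)C(=O)Nc1nc(-c2cc(C)on2)cs1` gives 1.3 mg/kg
compound 2 `O=C(O)C(=O)Nc1nc(-c2conc2-c2ccccc2)cs1` gives > 100 mg/kg (a limit)

In a functional assay on the whole organism with Rattus norvegicus as the target (a lower number here means that less compound is needed, a higher number that more compound is needed for the effect), compound 2 reads > 100 mg/kg as a limit of the assay and not a number. Compound 3 `O=C(O)C(=O)Nc1nc(-c2conc2-c2c(F)cccc2Cl)cs1` differs from compound 2 by 2-chloro-6-fluorophenyl in place of phenyl on an aromatic carbon. Within the data shown here, no measured pair shows the size of this change. The expected outcome is a number no higher from compound 2 to compound 3 (the limit leaves the size open) and nothing beyond the usual scatter. This expectation rests on compound 2 alone, with its limit of > 100 mg/kg as the only anchor. The estimate for compound 3 is 100 mg/kg within an expected range from 20 mg/kg to 300 mg/kg as the dose for half-maximal effect.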

Compound 3, dose for half-maximal effect: 30 mg/kg
Beside the measured number, compound 3's estimate is 3.3-fold (0.52 log units) above it; low and high end bracket the measured number.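

In this assay, 2-chloro-6-fluorophenyl in place of phenyl, on an aromatic carbon next to the ring nitrogen, gives an at least 3.3-fold lower number from compound 2 to compound 3 (0.52 log units; beyond the scatter), so this position responds to a change of aryl group. Compound 3 gives a measured number, whereas compound 2 gives only a limit. The full size of the step stays unknown because one end of it is that limit: the limit of > 100 mg/kg in this assay, at which 1 of the 3 values shown sits.

The compounds shown do not separate the chlorine from the fluorine as the source of the step. On these data alone, how a phenyl bearing a methoxy group or an amine would read at this position also stays open.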